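Shortening a Propyl Chain by One Carbon

The source may hold more compounds than are shown below. What is called first, only, known or untested is meant among the compounds shown, and "the series" means these compounds.

Of the compounds shown here, two have so far been tested in a functional assay on U-937 cells (Homo sapiens) for cytotoxicity, read by MTT assay, with a stated time of 24 h; a lower number here means a stronger inhibitor, a higher number a weaker inhibitor. Compound 1 `CCCCCCCCCCn1cc(-c2nc3ccccc3cc2CCC)nn1` gives 26.6 ug/mL in this assay, while compound 2 `CCCc1cc2ccccc2nc1-c1cn(-c2ccc(F)cc2)nn1` gives 67.4 ug/mL. Compound 1 thus holds the lowest of the two numbers, and the gap to compound 2 lies beyond the scatter, so compound 1 is the stronger of the pair. The two differ in several places at once, so their values show nothing about any single change.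

The next compound, compound 3 `CCCCCCCCCCn1cc(-c2nc3ccccc3cc2CC)nn1`, differs from compound 1 in one place only: hydrogen in place of methyl on a saturated chain carbon, two bonds along the chain from an aromatic carbon. Within the data shown here, no measured pair shows what this change does in this assay, so the expectation rests on the smallness of the change alone. A small step is expected, a 1.2-fold higher number from compound 1 to compound 3 (0.08 log units; within the scatter), either none beyond the scatter or slightly toward a weaker compound. Compound 3 is estimated at 32 ug/mL, with a range from 15 ug/mL to 70 ug/mL.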

Compound 3, half-maximal inhibitory concentration: 12.7 ug/mL
Estimate against measurement, compound 3: 2.5-fold (0.40 log units) above; measured number outside the range, below it.
By their numbers in this assay, from the lowest: compound 3; then compound 1; then compound 2.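

The change from propyl to ethyl gives a 2.1-fold lower number from compound 1 to compound 3 (0.32 log units; beyond the scatter) in this assay, the first step read at this position. Removing a single carbon from the chain moves the number beyond the scatter, so this chain is a place where even a small edit can register, and here the shorter chain goes with the stronger compound. Nothing available explains why this one carbon shifts the number.

Going by these compounds, a single step does not make a trend, so it remains open whether a methyl at this place would lower the number further or reverse the shift. Also open, on these data alone, are how a longer chain, a cyclopropyl ring or an amine on this chain would read, and whether the same shortening would have a similar effect alongside the other group carried by compound 2.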